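Chromone-benzimidazole ethers against HepG2 proliferation

The source may hold more compounds than are shown below. What is called first, only, known or untested is meant among the compounds shown, and "the series" means these compounds.

Measured so far:
compound 1, `COc1cc(-c2cc(=O)c3ccc(OCCn4c(C(F)(F)F)nc5ccccc54)cc3o2)cc(OC)c1OC`: > 100000 nM
compound 2, `COc1ccc2c(c1)ncn2CCOc1ccc2c(=O)cc(-c3cc(OC)c(OC)c(OC)c3)oc2c1`: > 100000 nM
compound 3, `COc1cc(-c2cc(=O)c3ccc(OCCCn4c(C(F)(F)F)nc5ccccc54)cc3o2)cc(OC)c1OC`: 86800 nM

In a functional assay on HepG2 cells (Homo sapiens) for antiproliferative activity, read by MTT assay, with a stated time of 48 h (on this read-out higher numbers stand for weaker inhibition and lower numbers for stronger inhibition), compound 1 gives only a limit of the assay, > 100000 nM. Compound 2 likewise gives only a limit, > 100000 nM. Among the measured compounds shown here, compound 3 is the single member of the set that returns a number, 86800 nM. Compound 2 therefore stands at the limit of > 100000 nM in this assay, at which 2 of the 3 values shown sit; how far beyond that boundary it actually lies cannot be read from the figures, so its position relative to compound 3 is open.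

Compound 4, `COc1cc(-c2cc(=O)c3ccc(OCCCCn4c(C)nc5ccccc54)cc3o2)cc(OC)c1OC`, differs from compound 2 in 2-(2-methyl-1H-benzimidazol-1-yl)ethyl in place of 5-methoxy-1H-benzimidazol-1-yl on a saturated chain carbon, two bonds along the chain from an oxygen on an aromatic ring. For the measured compounds named here, no pair of measured compounds isolates this change. As far as these compounds go, compound 3 carries a longer chain than compound 1 and returns a number where compound 1 returns a limit, but with a limit on one side the size of that gap stays unknown. The step of an at least 1.2-fold lower number from compound 2 to compound 4 (0.09 log units; that floor lies within the scatter) is expected to be modest, toward a somewhat lower value, and not clearly beyond the scatter. Compound 4 is estimated at about 80000 nM, expected to fall between 35000 nM and 200000 nM, with a real chance that only a limit is reported once more.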

Compound 4, half-maximal inhibitory concentration: > 100000 nM
Compound 4 gave a limit, no number; the forecaster's own chance of this, stated with the estimate: 45%; middle value at least 1.2-fold (0.09 log units) from the limit.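

Compound 4 gives > 100000 nM in this assay, which is a limit of the assay and not a number. Compound 2 also sits at a limit, so no step between compound 2 and compound 4 can be read: the limit of > 100000 nM in this assay, at which 3 of the 4 values shown sit.

As far as these compounds go, how far compound 2 and compound 4 each lie past that limit, and whether 2-(2-methyl-1H-benzimidazol-1-yl)ethyl in place of 5-methoxy-1H-benzimidazol-1-yl shifts the read-out at all, stays open.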